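The source may report more compounds than this note shows. Statements on the series, on what has been measured and on what is new or still open speak of the compounds shown alone.

Compound 1 `Fc1cccnc1O/N=C1/C=C(C#Cc2ccccn2)CCC1`: 4.01 nM
Compound 2 `Fc1cccc(O/N=C2\C=C(C#Cc3ccccn3)CCC2)n1`: 44 nM
Compound 3 `N#Cc1ccc(O/N=C2\C=C(C#Cc3ccccn3)CCC2)cc1F`: 49.8 nM

In an assay on brain (strain Sprague-Dawley) for displacement of a labelled ligand from metabotropic glutamate receptor 5 (Rattus norvegicus), with a stated time of 45 min (on this read-out higher numbers stand for weaker inhibition and lower numbers for stronger inhibition), compound 1 gives the lowest of the three numbers, and both compound 2 and compound 3 stand above it by steps that lie beyond the scatter. Compound 4 `FCCOCCO/N=C1/C=C(C#Cc2ccccn2)CCC1` differs from compound 1 in one place: 2-(2-fluoroethoxy)ethyl in place of 3-fluoropyridin-2-yl on an oxygen. For the measured compounds named here, no step between measured compounds of this kind is available, so the expectation rests on compound 1 alone and on the nature of the exchange, an aromatic ring giving way to an open chain. A modest loss of strength is expected, with the step from compound 1 to compound 4 estimated at a 3.7-fold higher number from compound 1 to compound 4 (0.57 log units; beyond the scatter). Compound 4 is therefore expected to give 15 nM, within a range from 3 nM to 80 nM.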

Compound 4, inhibition constant: 3.8 nM
For compound 4 the middle estimate is 3.9-fold (0.60 log units) above the measured one; the range from low to high includes it.
By their numbers in this assay, from the lowest: compounds 4 and 1 (each within the scatter of the next); then compounds 2 and 3 (each within the scatter of the next).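

In this assay, putting 2-(2-fluoroethoxy)ethyl in place of 3-fluoropyridin-2-yl on an oxygen gives a 1.1-fold lower number from compound 1 to compound 4 (0.02 log units; within the scatter), so the two compounds cannot be told apart. In this one pair, the oxygen bonded to the double-bonded nitrogen carries either an aromatic ring or an open chain with no ring, and the number stays within the scatter. Nothing measured here explains this match. On these data alone, whether a longer chain, or a chain ending in an amine or a hydroxyl group instead of fluorine, would give a similar number remains open.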